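From a methyl amide to a 4-chlorophenyl amide

The source may report more compounds than this note shows. Statements on the series, on what has been measured and on what is new or still open speak of the compounds shown alone.

Compound 3 `CNC(=O)c1cc(Oc2ccc(/C=C/c3ccncc3)cc2)ccn1` gives 13200 nM in a functional assay on A549 cells (Homo sapiens) for antiproliferative activity, read by CCK-8 assay, with a stated time of 48 h (a higher number here means a weaker inhibitor, a lower number a stronger inhibitor), compound 1 `CNC(=O)c1cc(Oc2ccc(/C=C/c3ccccn3)cc2)ccn1` gives 17400 nM and compound 2 `O=C(c1cc(Oc2ccc(/C=C/c3ccccn3)cc2)ccn1)N1CCCC1` gives 15600 nM, so all three sit within the scatter of one another. The steps of a 1.1-fold lower number from compound 1 to compound 2 (0.05 log units; within the scatter) and a 1.3-fold lower number from compound 1 to compound 3 (0.12 log units; within the scatter) were both within the scatter. Compound 4 `O=C(Nc1ccc(Cl)cc1)c1cc(Oc2ccc(/C=C/c3ccncc3)cc2)ccn1` differs from compound 3 by 4-chlorophenyl in place of methyl on an amide-type nitrogen. Among the compounds with values here, only the step from compound 1 to compound 2 touches the same amide nitrogen, and it stayed within the scatter; no measured step brings a ring onto that nitrogen, so the data give no direction. The step of a 1.5-fold lower number from compound 3 to compound 4 (0.17 log units; within the scatter) that this estimate means is expected to remain small, with a wide range allowed. Compound 4 is estimated at 9000 nM, between 2000 nM and 35000 nM.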

Compound 4, half-maximal inhibitory concentration: 62100 nM
The estimate for compound 4 lay 6.9-fold (0.84 log units) below the measured number, and the stated range ends below it.
By their numbers in this assay, from the lowest: compounds 3, 2 and 1 (each within the scatter of the next); then compound 4.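

Carrying 4-chlorophenyl in place of methyl on the amide-type nitrogen gave a 4.7-fold higher number from compound 3 to compound 4 (0.67 log units; beyond the scatter) in this assay, the first step in this set beyond the scatter. This nitrogen therefore does respond to what it carries, and here an aromatic ring with a chlorine goes with a weaker inhibitor, whereas the swap to pyrrolidin-1-yl had stayed within the scatter. Nothing measured here accounts for this step.

From the compounds shown here alone, whether an unsubstituted phenyl or a benzyl on that nitrogen would read like compound 3 or like compound 4 stays open. So does whether the ring or the chlorine carries the step.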